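Dropping Bromine from a Biaryl Bis-Chalcone Phenol

The source may report more compounds than this note shows. Statements on the series, on what has been measured and on what is new or still open speak of the compounds shown alone.

The study concerns three bis-chalcone phenols that share a methyl-substituted, hydroxylated core carrying two enone arms and a pendant aryl ring. Compound 1 `COc1ccc(/C=C/C(=O)c2c(C)cc(O)c(C(=O)/C=C/c3ccc(OC)cc3)c2-c2ccc(OCc3ccccc3)cc2)cc1` carries a benzyloxyphenyl pendant and methoxyphenyl arms; in an ADME assay on HEK293 cells (Homo sapiens) for cytotoxicity, read by MTT assay, with a stated time of 24 h (a higher number here means a weaker inhibitor, a lower number a stronger inhibitor), compound 1 gives 28000 nM. Compound 2 `Cc1cc(O)c(C(=O)/C=C/c2ccc(Br)cc2)c(-c2ccc(OCc3ccccc3)cc2)c1C(=O)/C=C/c1ccc(Br)cc1` keeps the benzyloxyphenyl pendant but has bromophenyl arms, and in this assay compound 2 gives 20000 nM. The two values lie within the scatter of each other. Compound 3 `COc1ccc(/C=C/C(=O)c2c(C)cc(O)c(C(=O)/C=C/c3ccc(OC)cc3)c2-c2ccc(Br)cc2)cc1` has methoxyphenyl arms and a bromophenyl pendant; in this assay compound 3 gives "not active" (no number reported), so no single number stands for it, and it cannot be placed against compounds 1 and 2.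

Compound 4 `COc1ccc(/C=C/C(=O)c2c(C)cc(O)c(C(=O)/C=C/c3ccc(OC)cc3)c2-c2ccccc2)cc1` differs from compound 3 by hydrogen in place of bromo on an aromatic carbon. Going by the values given here, no step between measured compounds covers this change. Since compound 3 gave no activity and compounds 1 and 2 sit weakly, any step in this assay is expected to be small, with no clear direction beyond the scatter. Compound 4 is therefore expected to come in near 40000 nM, estimated between 15000 nM and 100000 nM.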

Compound 4, half-maximal inhibitory concentration: "not active" (no number reported)
Nothing numeric was reported for compound 4; no gap can be computed for the estimate.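

Compound 3 and compound 4 both stand without a number in this assay, so no step can be read for the change from 4-bromophenyl to phenyl. The compounds shown leave open whether this change alters the read-out at all. No measured evidence bears on this result.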